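Removing the 4-methoxybenzyl group from compound 3

The source may hold more compounds than are shown below. What is called first, only, known or untested is meant among the compounds shown, and "the series" means these compounds.

In a functional assay on PC-3 cells (Homo sapiens) for inhibition, read by MTT assay, with a stated time of 48 h (a higher number here means a weaker inhibitor, a lower number a stronger inhibitor), three compounds that share one core have been measured. Compound 1 `CO[C@H]1C=C[C@H]2C/C=C\C[C@H](c3ccc(Br)cc3)OC(=O)C[C@@H]1O2` gives 15800 nM, compound 2 `COc1ccc(CO[C@H]2C=C[C@H]3C/C=C\C[C@H](c4ccc(F)cc4)OC(=O)C[C@@H]2O3)cc1` gives 2230 nM, and compound 3 `COc1ccc(CO[C@H]2C=C[C@H]3C/C=C\C[C@H](c4ccc5ccccc5c4)OC(=O)C[C@@H]2O3)cc1` gives 45400 nM. That last number is the highest of the three, which makes compound 3 the weakest inhibitor so far, with compound 1 its nearest neighbour.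

The next compound is compound 4 `O=C1C[C@@H]2O[C@@H](C=C[C@@H]2O)C/C=C\C[C@H](c2ccc3ccccc3c2)O1`, which changes compound 3 in one place: hydrogen in place of 4-methoxybenzyl on an oxygen on a saturated carbon. Cut one bond further out, the same difference reads (4-methoxybenzyl)oxy to hydroxy.

Among the measured compounds shown here, no measured step makes this change. For the measured compounds named here, the only step available, a 20-fold higher number from compound 2 to compound 3 (1.31 log units; beyond the scatter), is large, but it puts naphthalen-2-yl in place of 4-fluorophenyl on a saturated ring carbon, which is a different place in the molecule. It says little about the loss of 4-methoxybenzyl. Set against compound 3, from which it differs in more than one place, compound 1 also lacks 4-methoxybenzyl and has a lower number, at 15800 nM, so it is only a weak guide. A modest move towards a lower number is therefore expected, with low confidence. The expected change is a 2.3-fold lower number from compound 3 to compound 4 (0.36 log units; beyond the scatter). For compound 4 the estimated value is 20000 nM, with an expected range from 6000 nM to 60000 nM.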

Compound 4, half-maximal inhibitory concentration: 21500 nM
Estimate against measurement, compound 4: 1.1-fold (0.03 log units) below; low and high end bracket the measured number.
By their numbers in this assay, from the lowest: compound 2; then compounds 1 and 4 (each within the scatter of the next); then compound 3.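

In this assay, among the compounds shown here, the step of a 2.1-fold lower number from compound 3 to compound 4 (0.32 log units; beyond the scatter) gives the first direct reading of this position, and it shows that replacing the 4-methoxybenzyl group with hydrogen, which leaves a hydroxy group on the saturated carbon, produces a modest change that lies beyond the scatter. With naphthalen-2-yl on the shared core, the 4-methoxybenzyl group is therefore not required for a measurable inhibition, as compound 4 still gives 21500 nM without it, and in this one pair the lower number belongs to the compound that has lost the group and its aromatic ring. Nothing available here explains why the number moves in this direction.

From the compounds shown here alone, the change has been read only with naphthalen-2-yl in place, so it remains open whether losing 4-methoxybenzyl would give a step of the same direction and size in compound 2, which carries 4-fluorophenyl instead. Going by these compounds, it also remains open how the oxygen at this position would fare with an unsubstituted benzyl group, an acetyl group or a 2-aminoethyl chain in place of the hydrogen.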